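The source may report more compounds than this note shows. Statements on the series, on what has been measured and on what is new or still open speak of the compounds shown alone.

Of the compounds shown here, two have been measured in a physicochemical assay for lipophilicity; on this read-out lower numbers stand for lower lipophilicity and higher numbers for higher lipophilicity. In that assay compound 1 (`CCCCCCN(CCCCCSc1nc2cc(C)ccc2[nH]1)C(=O)Nc1ccc(F)cc1F`) gives 7.79, and compound 2 (`CCCCCCCN(CCCCCSc1ncccn1)C(=O)Nc1ccc(F)cc1F`) gives 5.41, the lower of the two numbers by more than the usual scatter. The account now follows the step to compound 3 (`CCCCCCCN(CCCCCSc1[nH]cnc2nncc1-2)C(=O)Nc1ccc(F)cc1F`), which has not yet been measured. The change sits on a sulfur whose other neighbour is a saturated chain carbon: a group of 9 heavy atoms (5 carbon, 4 nitrogen; one five-membered aromatic ring with 2 hetero atoms, one six-membered aromatic ring with 2 hetero atoms) in place of a group of 6 heavy atoms (4 carbon, 2 nitrogen; one six-membered aromatic ring with 2 hetero atoms), on a sulfur. The pyrimidin-2-yl group leaves, and the group that enters has no common name. No measured pair of compounds differs in one place only, so the data show no step for a change of this kind in this assay. Compound 2 and compound 1 differ in more than one place, so the value of compound 1, 7.79, is no direct guide. The expectation therefore starts from compound 2 at 5.41. A small downward change is expected, possibly none beyond the scatter, and the estimated step is a number 0.21 log units lower from compound 2 to compound 3 (within the scatter). For compound 3 the expected value is 5.2, with an estimated range from 4.4 to 6.1.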

Compound 3, partition coefficient: 5.6
Beside the measured number, compound 3's estimate is 0.40 log units below it, within the range that was stated.
By their numbers in this assay, from the lowest: compounds 2 and 3 (each within the scatter of the next); then compound 1.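

In this assay, putting the new group on the sulfur in place of the pyrimidin-2-yl group gives a number 0.19 log units higher from compound 2 to compound 3 (within the scatter), the first step read at this position, so compound 2 and compound 3 cannot be told apart on this read-out. The entering group has 9 heavy atoms, 1 hydrogen-bond donor and 3 hydrogen-bond acceptors against 6 heavy atoms, 0 hydrogen-bond donors and 2 hydrogen-bond acceptors in the group that leaves, and here these differences come with no step beyond the scatter. No measurement is available that would account for this result.

This single step leaves open whether other groups on the same sulfur, such as a phenyl ring, a group carrying an amine or one carrying a carboxylic acid, would also stay within the scatter of compound 2. It also leaves open whether the step would stay the same with a longer chain elsewhere in the molecule, and compound 1, which differs from compound 2 and from compound 3 in more than one place, cannot settle either question.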